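The source may report more compounds than this note shows. Statements on the series, on what has been measured and on what is new or still open speak of the compounds shown alone.

Compound 2 `COc1ccc(CNC(=O)/C=C/c2coc3cc(OC)ccc3c2=O)cc1` is known in a functional assay on L02 cells (Homo sapiens) for inhibition, read by MTT assay, with a stated time of 48 h (a lower number here means a stronger inhibitor, a higher number a weaker inhibitor), only by a limit: compound 2 gives > 200000 nM, which is a limit of the assay and not a number. Compound 1 `COc1ccc2c(=O)c(/C=C/C(=O)Nc3cccc(C)c3)coc2c1` likewise stops at a limit in this assay, giving > 200000 nM. The step that the two limits leave unreadable from compound 1 to compound 2 therefore cannot be read, and the whole record amounts to the limit of > 200000 nM in this assay, at which 2 of the 2 values shown sit. Compound 3 `COc1ccc2c(=O)c(/C=C/C(=O)Nc3ccccc3OC)coc2c1` differs from compound 2 by 2-methoxyphenyl in place of 4-methoxybenzyl on an amide-type nitrogen. Among the compounds with values here, no measured step bears on this change, so no direction can be inferred. Compound 3 is estimated in this assay at 300000 nM, between 100000 nM and 1000000 nM, most probably again only a limit. The expected step that the limit leaves unreadable from compound 2 to compound 3 is accordingly essentially none.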

Compound 3, half-maximal inhibitory concentration: > 200000 nM
Compound 3: no number, only a limit (the forecaster's own chance of this, stated with the estimate: 85%); the middle value is on the limit's open side.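

Compound 3 also stops at a limit, and its steps from compound 1 and compound 2 cannot be read: the limit of > 200000 nM in this assay, at which 3 of the 3 values shown sit.

The compounds shown leave open where the true values of compound 1, compound 2 and compound 3 lie in this assay, and whether their different groups on the amide nitrogen change them at all.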